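This account rests on a few compounds, and the source may have more. Where it says the series, first, only, none or still open, it means among the compounds named here.

Measured in an ADME assay on a cell-free system (plasma, Homo sapiens) for metabolic stability, with Plasma (Rattus norvegicus) as the target; on this read-out lower numbers stand for a shorter-lived compound and higher numbers for a longer-lived compound:
compound 1 `CCCCOc1nc(N)c2[nH]c(=O)n(Cc3cccc(C(=O)OC)c3)c2n1`: > 1.63 h (limit)
compound 2 `CCCCOc1nc(N)c2[nH]c(=O)n(Cc3ccc(C(=O)OC)cc3)c2n1`: > 1.63 h (limit)

Compound 1 stands at > 1.63 h, which is a limit of the assay and not a number. Both measured compounds share that one limit: the limit of > 1.63 h in this assay, at which 2 of the 2 values shown sit.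

Compound 3 `CCCCOc1nc(N)c2[nH]c(=O)n(Cc3cccc(C(C)C(=O)OC)c3)c2n1` carries 1-(methoxycarbonyl)ethyl in place of methoxycarbonyl on an aromatic carbon. No measured step sizes this change. In this assay a shorter-lived compound is expected, by a step beyond the scatter: the estimated change is an at least 3.2-fold lower number from compound 1 to compound 3 (0.51 log units; beyond the scatter). The estimate for compound 3 is 0.5 h, with an expected range of 0.1 h to 1.6 h.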

Compound 3, half-life: > 1.63 h
Compound 3 was reported as a limit; the forecaster's own chance of this, stated with the estimate: 25%; middle value at least 3.2-fold (0.51 log units) from the limit.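

No step can be read from compound 1 to compound 3, since both values are limits and not numbers: the limit of > 1.63 h in this assay, at which 3 of the 3 values shown sit.

The compounds shown leave open whether 1-(methoxycarbonyl)ethyl in place of methoxycarbonyl changes the half-life at all.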